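Lengthening the alkyne side chain of a hydroxyurea inhibitor

The source may report more compounds than this note shows. Statements on the series, on what has been measured and on what is new or still open speak of the compounds shown alone.

Compound 1 `C[C@@H](C#Cc1cccc(C(=O)NCc2ccccc2C(F)(F)F)c1)N(O)C(N)=O` is one of two measured compounds. In an assay for inhibition of Polyunsaturated fatty acid 5-lipoxygenase (Homo sapiens), read by HPLC, with stated times of 15 min and 10 min (on this read-out lower numbers stand for stronger inhibition and higher numbers for weaker inhibition), compound 1 gives 700 nM, the lowest of the two numbers, while compound 2 `CC(C#Cc1cccc(C(=O)NCc2ccc(F)cc2C(F)(F)F)c1)N(O)C(N)=O` in this assay gives 1300 nM. These two values lie within the usual scatter of each other, so no order can be read from them. Compound 3 `CCC(C#Cc1cccc(C(=O)NCc2ccccc2C(F)(F)F)c1)N(O)C(N)=O` differs from compound 1 in a single place: 1-(carbamoyl(hydroxy)amino)propyl in place of 1-(carbamoyl(hydroxy)amino)ethyl on a triple-bonded carbon. Going by the values given here, no measured pair shows this change, so there is no step from which its size could be read. The data give no reason to look for a move beyond the scatter in either direction. Compound 3 is therefore expected to give 900 nM in this assay, with a range from 300 nM to 2700 nM. The estimated step of a 1.3-fold higher number from compound 1 to compound 3 (0.11 log units; within the scatter) is expected to stay within the scatter of repeated measurements.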

Compound 3, half-maximal inhibitory concentration: 500 nM
Compound 3: the middle estimate sits 1.8-fold (0.26 log units) above what was measured, and the stated range covers the measured number.
By their numbers in this assay, from the lowest: compounds 3, 1 and 2 (each within the scatter of the next, the first and the last beyond it).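

In this assay, going by these compounds alone, 1-(carbamoyl(hydroxy)amino)propyl in place of 1-(carbamoyl(hydroxy)amino)ethyl on a triple-bonded carbon gives a 1.4-fold lower number from compound 1 to compound 3 (0.15 log units; within the scatter) and so offers the first reading of a change at this position, which takes the propyl group without a move beyond the scatter. The step also carries a second difference, since the group that leaves has a defined stereocentre and the group that enters has none, so the effects of chain length and stereochemistry cannot be separated here. Nothing on hand explains the step.

As far as these compounds go, whether a longer chain, such as 1-(carbamoyl(hydroxy)amino)butyl, or a cyclopropyl group at this place would also stay within the scatter remains open. So does whether the two mirror-image forms of compound 3 would give different numbers.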